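A few compounds are considered here, and "the series" means these few. Any claim that something is new, unique, unknown or untested is made for them only; others in the source may bear on it.

Among the compounds with values here, compound 1 `CN(C)C(=O)C1CCN(c2ccc(Cl)c(C(F)(F)F)c2)C1` gives 1200 nM in an assay on cells for inhibition of Palmitoleoyl-protein carboxylesterase NOTUM variant C330S (Homo sapiens), read by fluorescence, with a stated time of 40 min (on this read-out lower numbers stand for stronger inhibition and higher numbers for weaker inhibition), the lowest of the two numbers measured so far. Compound 2 `CN1CCN(C(=O)C2CCN(c3ccc(Cl)c(C(F)(F)F)c3)C2)CC1=O` gives 3100 nM in this assay; the step of a 2.6-fold higher number from compound 1 to compound 2 (0.41 log units; beyond the scatter) was modest. Compound 3 `FC(F)(F)c1cc(N2CCC(c3nnco3)C2)ccc1Cl` carries a different change: 1,3,4-oxadiazol-2-yl in place of dimethylcarbamoyl on a saturated ring carbon. Within the data shown here, the single measured step altered only the group attached to the carbonyl carbon, whereas this exchange removes the carbonyl altogether, so it bears only loosely here and the estimate is tentative. Compound 3 is therefore expected to show a step of a 1.5-fold lower number from compound 1 to compound 3 (0.18 log units; within the scatter), an estimated 800 nM with a range from 200 nM to 4000 nM.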

Compound 3, half-maximal inhibitory concentration: 24000 nM
Compound 3: middle estimate off by 30-fold (1.48 log units), on the low side, outside the stated range (above it).
By their numbers in this assay, from the lowest: compound 1; then compound 2; then compound 3.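

At this saturated ring carbon, the group on the carbonyl can change with only a modest shift (a 2.6-fold higher number from compound 1 to compound 2 (0.41 log units; beyond the scatter)). Replacing the whole dimethylcarbamoyl with 1,3,4-oxadiazol-2-yl, which has the same count of heavy atoms, gives a far larger shift (a 20-fold higher number from compound 1 to compound 3 (1.30 log units; beyond the scatter)), so similar size alone does not preserve inhibition here. Nothing available explains this result. From the compounds shown here alone, it remains open whether the carbonyl or the new ring accounts for the shift. A methyl ester, which keeps a carbonyl, or a 1,2,4-oxadiazol-3-yl ring at this carbon could help separate the two.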